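A few compounds are considered here, and "the series" means these few. Any claim that something is new, unique, unknown or untested is made for them only; others in the source may bear on it.

In a functional assay (brain) for inhibition, with Rattus norvegicus as the target (a lower number here means a stronger inhibitor, a higher number a weaker inhibitor), compound 1 `CCCCCCCCCOC1=C(O)OC(C(O)CO)C1=O` gives 0.027 nM, while compound 2 `CCCCCCCCCCCCCCCOC1=C(O)OC(C(O)CO)C1=O` gives 5600 nM, the higher of the two numbers and so the weaker inhibitor. The change from compound 2 to compound 3 `CCCCCCCCCCCCCCCCOC1=C(O)OC(C(O)CO)C1=O` is methyl in place of hydrogen on a saturated chain carbon, ten or more bonds along the chain from an oxygen on an unsaturated carbon. Going by the values given here, the only measured step bearing on this, a 210000-fold higher number from compound 1 to compound 2 (5.32 log units; beyond the scatter), is large and extends the same chain by much more, so a far smaller rise in the same direction is expected in this assay, although a single step fixes no trend. The expected step is a 1.8-fold higher number from compound 2 to compound 3 (0.25 log units; within the scatter). Compound 3 is estimated at 10000 nM, with an expected range of 1500 nM to 80000 nM.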

Compound 3, half-maximal inhibitory concentration: 6800 nM
Compound 3: middle estimate off by 1.5-fold (0.17 log units), on the high side; the measured number falls inside the stated range.
By their numbers in this assay, from the lowest: compound 1; then compounds 2 and 3 (each within the scatter of the next).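

In this assay, methyl in place of hydrogen at this place on the chain reads a 1.2-fold higher number from compound 2 to compound 3 (0.08 log units; within the scatter) and so, unlike the earlier hexyl change, separates the two compounds by no more than the scatter. Heptyl in place of hydrogen reads a 250000-fold higher number from compound 1 to compound 3 (5.40 log units; beyond the scatter) and so keeps the large step, which the extension beyond compound 2 does not visibly add to. No evidence bears on this flat stretch of the chain. Where between the chain lengths of compound 1 and compound 2 the number rises stays open. So does the effect of a longer chain, or of an amine or carboxylic acid in place of this methyl.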